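The source may hold more compounds than are shown below. What is called first, only, known or untested is meant among the compounds shown, and "the series" means these compounds.

Values measured in a physicochemical assay for lipophilicity, in phosphate buffer, measured as octanol-water partition; a lower number here means a more polar compound, a higher number a more lipophilic compound:

compound 1 `Cc1nc2ccccc2c(=O)n1/N=C/c1ccc(Oc2ccc(Cl)cc2)cc1` — 4.6
compound 2 `O=c1c2ccccc2nc(-c2ccccc2)n1/N=C/c1ccc(Oc2ccc(Br)cc2)cc1` — 6.39
compound 3 `CCCc1nc2ccccc2c(=O)n1/N=C/c1ccc(Oc2ccc(Cl)c(C)c2)cc1` — 6.02

Within these three numbers compound 3 stands second highest. Its nearest neighbour is compound 2, whose value lies higher by an amount beyond the scatter; the furthest is compound 1, whose value lies lower, again beyond the scatter. Within the data shown here, no pair among the three differs in a single place, so no step between measured compounds can be read off directly; the values show only that compound 1 sits well apart from compound 2 and compound 3.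

Compound 4 `CCCc1nc2ccccc2c(=O)n1/N=C/c1ccc(Oc2ccc(Br)cc2)cc1` is the next member of the series and has not yet been run in this assay. It follows from compound 3 by one change: 4-bromophenyl in place of 4-chloro-3-methylphenyl on an oxygen on an aromatic ring.

Among the measured compounds shown here, with no measured step of this kind available, the expectation rests on the change itself: one heavy atom fewer, the methyl gone, chlorine exchanged for bromine. The step from compound 3 to compound 4 in this assay is expected to be small and, if anything, downward, most likely within the scatter: a number 0.22 log units lower from compound 3 to compound 4 (within the scatter). Compound 4 is therefore estimated at 5.8, with a range from 5.2 to 6.4.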

Compound 4, partition coefficient: 5.88
For compound 4 the middle estimate is 0.08 log units below the measured one; the range from low to high includes it.
By their numbers in this assay, from the lowest: compound 1; then compounds 4 and 3 (each within the scatter of the next); then compound 2.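

In this assay, among these compounds, 4-bromophenyl in place of 4-chloro-3-methylphenyl on an oxygen on an aromatic ring gives the only measured step at this position, a number 0.14 log units lower from compound 3 to compound 4 (within the scatter), so this exchange does not separate the two compounds. Compound 4 also gives a reading at a second position: propyl in place of phenyl on an aromatic carbon gives a number 0.51 log units lower from compound 2 to compound 4 (beyond the scatter), a modest step, but it rests on this single pair and sets no pattern for the series. No measurement shown here bears on the origin of either step.

Compound 1 differs from every other compound shown in more than one place, so no step to it can be read, and what the methyl of compound 1 contributes on the aromatic carbon stays unseparated from the change in halogen. Also open, on these data alone, is where a longer chain such as butyl on that aromatic carbon, or an amine or a carboxylic acid in place of the bromine of compound 4, would fall in this assay.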